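Two Amino-Alcohol Ethers Ahead of a Cytotoxicity Read-Out

The source may report more compounds than this note shows. Statements on the series, on what has been measured and on what is new or still open speak of the compounds shown alone.

Compound 1 `O=c1cc(OCC(O)CNC2CCCCC2)c2ccccc2o1` was run in an ADME assay on Vero cells (Chlorocebus sabaeus) for cytotoxicity, read by fluorescence and resazurin assay, with a stated time of 72 h; on this read-out lower numbers stand for higher toxicity in this test and higher numbers for lower toxicity in this test. In this assay compound 1 gives > 100000 nM, which is a limit of the assay rather than a number. Compound 2 `O=C(O)CCCNCC(O)COc1cc(=O)oc2ccccc12` carries the same core, yet in this assay compound 2 stands at "not determined" (no result reported), so no number places it anywhere. What the shown values offer is only this: the limit of > 100000 nM in this assay, at which 1 of the 2 values shown sits. Compound 3 `CN1CCN(CC(O)COc2cc(=O)oc3ccccc23)CC1` differs from compound 2 by 4-methylpiperazin-1-yl in place of (3-carboxypropyl)amino on a saturated chain carbon, two bonds along the chain from an oxygen on a saturated carbon. For the measured compounds named here, no measured pair shows how this kind of change moves the read-out, so the step from compound 2 to compound 3 has no size that can be read off, and nothing beyond the usual scatter is expected in either direction. For compound 3 in this assay the expected half-maximal cytotoxic concentration is 100000 nM, with an expected range from 30000 nM to 300000 nM.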

Compound 3, half-maximal cytotoxic concentration: > 100000 nM
Compound 3: only a limit was reported; the forecaster's own chance of this, stated with the estimate: 70%; the middle value lies on the limit itself.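

Compound 1 and compound 3 both rest on a limit of the assay in this assay, so no step can be read from compound 1 to compound 3: the limit of > 100000 nM in this assay, at which 2 of the 3 values shown sit.

The compounds shown leave open whether 4-methylpiperazin-1-yl, cyclohexylamino or (3-carboxypropyl)amino moves this read-out at all.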